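The compounds below may be only part of what the source reports. "The series", "measured", "known", "first", "only" and "open" are said of these compounds alone.

In a functional assay on HL-60 cells (Homo sapiens) for inhibition, read by CCK-8 assay, with a stated time of 48 h (on this read-out higher numbers stand for weaker inhibition and lower numbers for stronger inhibition), compound 3 (`O=[N+]([O-])c1ccc(NC(=S)NCCNS(=O)(=O)c2ccc(-c3ccccc3OCc3ccccc3)s2)cc1`) gives > 50000 nM as a limit of the assay and not a number. Compound 2 (`O=[N+]([O-])c1ccc(NC(=S)NCCNS(=O)(=O)c2ccc(-c3ccccc3O[C@H]3CC[C@@H](O)CC3)s2)cc1`) gives > 50000 nM in this assay and this too is only a limit. Compound 3 thus stands at the limit of > 50000 nM in this assay, at which 2 of the 3 values shown sit, with no number to start from.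

For the measured compounds named here, the one measured change in a single place is a step that the two limits leave unreadable from compound 2 to compound 3 and it offers no size to carry forward. Going by the values given here, compound 4 (`O=[N+]([O-])c1ccc(NC(=S)NCCNS(=O)(=O)c2ccc(-c3ccccc3OCc3cccc(O)c3)s2)cc1`) is compound 3 with hydroxy in place of hydrogen on an aromatic carbon as its only change: hydroxy in place of hydrogen on an aromatic carbon, or benzyl to 3-hydroxybenzyl.

Compound 1 (`O=S(=O)(NCCNC(=S)Nc1cccc(Cl)c1)c1ccc(-c2ccccc2OCc2cccc(O)c2)s1`) also carries the 3-hydroxybenzyl group and gives 1800 nM in this assay as a true number. Among the compounds with values here, no measured step ties compound 1 to this change, so it is weak support and the only support. On the strength of compound 1 at 1800 nM alone, the direction expected is toward stronger inhibition. The expected shift is an at least 8.3-fold lower number from compound 3 to compound 4 (0.92 log units; beyond the scatter) and another reading at the limit remains possible. For compound 4 the estimate is 6000 nM with an expected range from 1000 nM to 40000 nM for the measurement.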

Compound 4, half-maximal inhibitory concentration: 10800 nM
The estimate for compound 4 lay 1.8-fold (0.26 log units) below the measured number; the measured number falls inside the stated range.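

Hydroxy in place of hydrogen on an aromatic carbon, meta to a large group, is the first change shown that brings a 4-nitrophenyl compound in this assay off the limit, with an at least 4.6-fold lower number from compound 3 to compound 4 (0.66 log units; beyond the scatter). The comparison with 4-hydroxycyclohexyl on the same oxygen points the same way, with an at least 4.6-fold lower number from compound 2 to compound 4 (0.66 log units; beyond the scatter), so among these compounds a hydroxy-bearing group on that oxygen is not enough by itself and the 3-hydroxybenzyl group is the one that gives a number. The 3-hydroxybenzyl group does not set the level alone, since the group on the amide-type nitrogen also counts, with a 6.0-fold higher number from compound 1 to compound 4 (0.78 log units; beyond the scatter).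

As far as these compounds go, the true size of the two steps to compound 4 stays open and the step between compound 2 and compound 3 cannot be read, because neither of those compounds gives a number: the limit of > 50000 nM in this assay, at which 2 of the 4 values shown sit. Also open is whether an amine or a carboxylic acid in place of the hydroxy would hold the level of compound 4, and whether the 3-chlorophenyl group would lift compound 3 off the limit without any hydroxy.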